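The source may hold more compounds than are shown below. What is called first, only, known or untested is meant among the compounds shown, and "the series" means these compounds.

Measured so far:
compound 1 `Cc1nc(-c2ccc(C(F)(F)F)cc2)sc1CNc1ccc(CCC(=O)O)cc1` — in a functional assay on CHO cells for agonist activity at Free fatty acid receptor 1 (Homo sapiens) (on this read-out higher numbers stand for an effect only at larger amounts of compound and lower numbers for an effect already at smaller amounts), compound 1 gives 67.6 nM.
compound 2 `O=C(O)c1ccc(NCc2cccc(Oc3ccccc3)c2)cc1` — in this assay compound 2 gives only a limit, < 10000 nM.

Within the data shown here, compound 1 holds the only full number in this assay; the other value shown is the limit of < 10000 nM in this assay, at which 1 of the 2 values shown sits. Compound 3 `Cc1nc(-c2ccc(C(F)(F)F)cc2)sc1CNc1ccc(C(=O)O)cc1` is not yet measured. It differs from compound 1 by carboxy in place of 2-carboxyethyl on an aromatic carbon. Among the measured compounds shown here, no measured pair shows this change, so its size is open; a loss of potency beyond the usual scatter is expected, roughly an 8.9-fold higher number from compound 1 to compound 3 (0.95 log units; beyond the scatter). Compound 3 is estimated at 600 nM, within 150 nM to 3000 nM.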

Compound 3, half-maximal effective concentration: < 10000 nM
Compound 3 was reported as a limit; the forecaster's own chance of this, stated with the estimate: 20%; the middle value lies beyond the limit too.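

Compound 3 gives only a limit in this assay, so no step from compound 1 to compound 3 can be read: the limit of < 10000 nM in this assay, at which 2 of the 3 values shown sit.

The compounds shown leave open how large the change from 2-carboxyethyl to carboxy is on the core of compound 1.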